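The source may report more compounds than this note shows. Statements on the series, on what has been measured and on what is new or still open speak of the compounds shown alone.

Compound 1 `O=C(Nc1cccc(-c2ccoc2)c1)C(Cl)Cl` carries a furan-3-yl group on the shared core, and in a functional assay on NCI-H460 cells (Homo sapiens) for cytotoxicity, read by MTT assay, with a stated time of 68 h (on this read-out higher numbers stand for weaker inhibition and lower numbers for stronger inhibition), compound 1 gives 37600 nM. Compound 2 `O=C(Nc1cccc(-c2ccc(Cl)cc2)c1)C(Cl)Cl` carries a 4-chlorophenyl group instead; in this assay compound 2 reaches only a limit of the assay, > 50000 nM. Compound 3 `O=C(Nc1cccc(-c2ccccn2)c1)C(Cl)Cl` carries a pyridin-2-yl group; in this assay compound 3 likewise returns only a limit, > 50000 nM. Compound 3 therefore stands at the edge of what the assay can report, the point where two of the three values sit (the limit of > 50000 nM in this assay, at which 2 of the 3 values shown sit). Within the data shown here, the single counted step, an at least 1.3-fold higher number from compound 1 to compound 3 (0.12 log units; that floor lies within the scatter), is a floor that lies within the scatter.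

Compound 4 `O=C(Nc1cccc(-c2ccccc2)c1)C(Cl)Cl` differs from compound 3 in one place: phenyl in place of pyridin-2-yl on an aromatic carbon. Among the measured compounds shown here, no measured step involves phenyl itself, so the expectation rests on the three values together, all of which sit at or close to the limit. The step of an at least 1.1-fold lower number from compound 3 to compound 4 (0.04 log units; that floor lies within the scatter) is expected to stay within the scatter. Compound 4 is therefore estimated to give 45000 nM, with a range from 20000 nM to 100000 nM.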

Compound 4, half-maximal inhibitory concentration: 20200 nM
Estimate against measurement, compound 4: 2.2-fold (0.35 log units) above; the measured number falls inside the stated range.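

Phenyl on this aromatic carbon, meta to the ((dichloromethyl)carbonyl)amino group, gives an at least 2.4-fold lower number from compound 3 to compound 4 (0.39 log units; beyond the scatter) and so provides the first step in the series that lies beyond the scatter. Hydrogen in place of chloro on the phenyl ring gives an at least 2.4-fold lower number from compound 2 to compound 4 (0.39 log units; beyond the scatter) and shows that the 4-chloro substituent also matters at this position. The change from furan-3-yl gives a 1.9-fold lower number from compound 1 to compound 4 (0.27 log units; within the scatter) and so places neither group ahead of the other.

Going by these compounds, the true size of the first two steps stays open because compound 2 and compound 3 return only limits and not numbers: the limit of > 50000 nM in this assay, at which 2 of the 4 values shown sit. The compounds shown also leave open how an amine or a carboxylic acid on the phenyl ring, or a longer chain in its place, would read in this assay at this position.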